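Thiosemicarbazone hydrazones: aryl swap on the imine carbon

A few compounds are considered here, and "the series" means these few. Any claim that something is new, unique, unknown or untested is made for them only; others in the source may bear on it.

Measured so far in a functional assay on NCI-H460 cells (Homo sapiens) for inhibition, read by sulforhodamine B assay, with a stated time of 48 h; on this read-out lower numbers stand for stronger inhibition of growth and higher numbers for weaker inhibition of growth:
compound 1 `CC1=CC[C@H](C(C)(C)NC(=S)NN)CC1`: 42000 nM
compound 2 `CC1=CC[C@H](C(C)(C)NC(=S)N/N=C/c2ccccc2Cl)CC1`: 64500 nM

For the measured compounds named here, compound 2 gives one of only two numbers in this assay; the other, that of compound 1, lies within the scatter of it, so the two compounds cannot be told apart on these data. Compound 3 `CC1=CC[C@H](C(C)(C)NC(=S)N/N=C/c2cccs2)CC1` carries the change (thiophen-2-yl in place of 2-chlorophenyl on a carbon with a double bond to nitrogen), thiophen-2-yl in place of 2-chlorophenyl on a carbon with a double bond to nitrogen. Going by the values given here, no step between measured compounds exists to guide this change, and the two values in hand show no separation. The expected step in this assay is therefore none beyond the scatter, with no direction preferred: a 1.1-fold lower number from compound 2 to compound 3 (0.03 log units; within the scatter). On that basis compound 3 is estimated at 60000 nM, with a range from 20000 nM to 180000 nM.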

Compound 3, concentration for 50% growth inhibition: 10800 nM
The estimate for compound 3 lay 5.6-fold (0.74 log units) above the measured number; the measured number lies below the stated range.
By their numbers in this assay, from the lowest: compound 3; then compounds 1 and 2 (each within the scatter of the next).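

In this assay the carbon with a double bond to nitrogen now separates compounds: thiophen-2-yl in place of 2-chlorophenyl gives a 6.0-fold lower number from compound 2 to compound 3 (0.78 log units; beyond the scatter), so the number at this position depends on which aromatic ring it carries. The comparison with the compound lacking the imine substituent gives a 3.9-fold lower number from compound 1 to compound 3 (0.59 log units; beyond the scatter), whereas compound 2 stays within the scatter of compound 1, so adding an aromatic ring here does not in itself lower the number. Nothing in hand accounts for the step.

Open, going by these compounds, is whether the step follows from the five-membered ring, its sulfur, or the loss of the chlorine. A plain phenyl, a furan-2-yl or a pyridin-2-yl group on this carbon would separate these readings.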